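Replacing a 1-carboxyethyl Group with (Methoxycarbonyl)methyl

The compounds below may be only part of what the source reports. "The series", "measured", "known", "first", "only" and "open" are said of these compounds alone.

Measured compounds:
compound 1 `C=C(CCCC)C(=O)c1ccc(OCC(=O)OC)c(C)c1C` gives 8600 nM
compound 2 `C=C(CCC)C(=O)c1ccc(OC(C)C(=O)O)c(C)c1C` gives 11200 nM

Of the compounds shown here, two have been measured in a functional assay on HL-60 cells (Homo sapiens) for antiproliferative activity, with a stated time of 72 h; a higher number here means a weaker inhibitor of growth, a lower number a stronger inhibitor of growth. Compound 2 has the higher of the two numbers, and compound 1 sits only a little lower, a gap that lies within the usual scatter of this kind of measurement, so the two cannot be told apart on these data.

Compound 3 `C=C(CCC)C(=O)c1ccc(OCC(=O)OC)c(C)c1C` has not yet been measured. It shares its core with compound 2 and differs from it at one place: (methoxycarbonyl)methyl in place of 1-carboxyethyl on an oxygen on an aromatic ring. Going by the values given here, the two compounds contain the same atoms, arranged differently, and the group that enters is the one that compound 1 also carries on the oxygen on the aromatic ring.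

Among the compounds with values here, no step between measured compounds is available to calibrate this change. With compound 1 and compound 2 so close in this assay, no step beyond the scatter is expected in either direction from compound 2 to compound 3, a 1.2-fold lower number from compound 2 to compound 3 (0.07 log units; within the scatter). Compound 3 is therefore estimated at 9500 nM, with a likely range from 3500 nM to 26000 nM.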

Compound 3, concentration for 50% growth inhibition: 8600 nM
Beside the measured number, compound 3's estimate is 1.1-fold (0.04 log units) above it; measured number inside the range.
By their numbers in this assay, from the lowest: compounds 1, 3 and 2 (each within the scatter of the next).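

The step of a 1.3-fold lower number from compound 2 to compound 3 (0.11 log units; within the scatter) shows that in this assay this exchange of groups on an oxygen on an aromatic ring leaves compound 2 and compound 3 indistinguishable, even though the hydrogen-bond donor of 1-carboxyethyl is absent from (methoxycarbonyl)methyl. Compound 1 and compound 2 differ in more than one place, whereas compound 3 now allows each difference to be read alone. With hydrogen in place of methyl on a saturated chain carbon, three bonds along the chain from a double-bonded chain carbon, the step reads no change at the digits printed from compound 1 to compound 3 (within the scatter) and is also within the scatter, so neither single change separates these compounds in this assay.

On these data alone, two features change together in the exchange on the oxygen, the acid becoming a methyl ester and the methyl on the carbon bearing the carbonyl going away, so their separate contributions remain open. Carboxymethyl and 1-(methoxycarbonyl)ethyl would each carry only one of those features, and an amide in place of the ester is equally unexplored in the compounds shown. No supporting measurement is available to explain the size of either step.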